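The source may hold more compounds than are shown below. What is called first, only, known or untested is meant among the compounds shown, and "the series" means these compounds.

Compound 1, `O=C(c1ccc(-c2nc(-c3cccnc3)no2)s1)C(F)(F)F`: 70 nM
Compound 2, `O=C(c1ccc(-c2nc(-c3ccc(F)cc3F)no2)s1)C(F)(F)F`: 120 nM

These two compounds share the same core and differ only in the aromatic group attached to it. In an assay for inhibition of histone deacetylase 4 (Homo sapiens) (a lower number here means a stronger inhibitor, a higher number a weaker inhibitor), compound 2 gives 120 nM. Among the compounds with values here, its only measured neighbour, compound 1, gives 70 nM, and the step of a 1.7-fold higher number from compound 1 to compound 2 (0.23 log units; within the scatter) is too small to tell the two apart.

Compound 3, `O=C(c1ccc(-c2nc(-c3ccc(Cl)cc3Cl)no2)s1)C(F)(F)F`, has not yet been measured in this assay. It is derived from compound 2 by the change (2,4-dichlorophenyl in place of 2,4-difluorophenyl on an aromatic carbon). Within the data shown here, no measured step involves an exchange of fluorine for chlorine, so nothing in the data speaks directly to this change. Among the measured compounds shown here, the single measured step, from compound 1 to compound 2, altered a different group at the same position and stayed within the scatter, which gives no reason to expect a large shift here either. For compound 3 the expected step is no change at the digits printed from compound 2 to compound 3 (within the scatter), that is, none beyond the scatter. Compound 3 is therefore estimated at 120 nM, with a range from 40 nM to 360 nM.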

Compound 3, half-maximal inhibitory concentration: 240 nM
Compound 3: middle estimate off by 2.0-fold (0.30 log units), on the low side, and the stated range covers the measured number.
By their numbers in this assay, from the lowest: compounds 1, 2 and 3 (each within the scatter of the next, the first and the last beyond it).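

In this assay, exchanging the two fluorines of 2,4-difluorophenyl for the two chlorines of 2,4-dichlorophenyl gives a 2.0-fold higher number from compound 2 to compound 3 (0.30 log units; within the scatter) and so cannot be told apart from the ordinary spread of repeated measurements. Within the data shown here, the comparison with the pyridin-3-yl group of compound 1 adds something the first pair could not show: 2,4-dichlorophenyl in its place gives a 3.4-fold higher number from compound 1 to compound 3 (0.54 log units; beyond the scatter) and is the first step in this set to clear the scatter, although only modestly, so the group on this aromatic carbon can move the number. Nothing available accounts for this difference between the two groups.

The compounds shown leave open how an unsubstituted phenyl, a 4-chlorophenyl or a 4-methoxyphenyl group would read at this position, and such groups could help separate the role of the halogens from that of the ring itself. They also leave open whether a bromine-bearing ring, or a ring carrying an amine or a carboxylic acid, would continue the small drift seen here or break from it.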